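The compounds below may be only part of what the source reports. "The series", "measured", "known", "first", "only" and "open" are said of these compounds alone.

Measured in a functional assay on MCF7 cells (Homo sapiens) for inhibition, read by resazurin assay, with a stated time of 72 h; on this read-out lower numbers stand for stronger inhibition and higher numbers for weaker inhibition:
compound 1 `C=CC1C(=O)N(c2cc(OC)c(OC)c(OC)c2)C1c1ccc(SC)cc1` gives 51 nM
compound 2 `COc1cc(N2C(=O)C(Oc3ccccc3)C2c2ccc(SC)cc2)cc(OC)c1OC` gives 152 nM
compound 3 `CCOc1ccc(C2C(Oc3ccccc3)C(=O)N2c2cc(OC)c(OC)c(OC)c2)cc1` gives 69 nM

Compound 4 `C=CC1C(=O)N(c2cc(OC)c(OC)c(OC)c2)C1c1ccc(OCC)cc1` is not yet measured. It comes from compound 3 by vinyl in place of phenoxy on a saturated ring carbon. The same kind of change has been made once before, between two measured compounds: compound 1 comes from compound 2 by vinyl in place of phenoxy on a saturated ring carbon, and that step gave a 3.0-fold lower number from compound 2 to compound 1 (0.47 log units; beyond the scatter). The two cores differ by ethoxy in place of methylsulfanyl on an aromatic carbon, a step of a 2.2-fold lower number from compound 2 to compound 3 (0.34 log units; beyond the scatter). Around the place the two changes are not identical: in one the changed carbon is next to the ring atom that bears a 4-(methylsulfanyl)phenyl group (8 heavy atoms), in the other next to the ring atom that bears a 4-ethoxyphenyl group (9 heavy atoms).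

Because a 3.0-fold lower number from compound 2 to compound 1 (0.47 log units; beyond the scatter) was modest but beyond the scatter, a step of similar size is expected from compound 3, namely a 2.6-fold lower number from compound 3 to compound 4 (0.41 log units; beyond the scatter), tempered somewhat since it rests on a single precedent. Compound 4 is thus estimated at 27 nM, expected between 12 nM and 60 nM.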

Compound 4, half-maximal inhibitory concentration: 14 nM
Compound 4: the middle estimate sits 1.9-fold (0.29 log units) above what was measured; the range from low to high includes it.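

In this assay, vinyl in place of phenoxy on the saturated ring carbon again lowers the number, giving a 4.9-fold lower number from compound 3 to compound 4 (0.69 log units; beyond the scatter) and the two instances of this change agree: the same change on two cores in this assay, a 3.0-fold lower number (0.47 log units; beyond the scatter) from compound 2 to compound 1 and a 4.9-fold lower number (0.69 log units; beyond the scatter) from compound 3 to compound 4, 1.7-fold (0.22 log units) apart, within the scatter of two such steps. Ethoxy in place of methylsulfanyl gives a 3.6-fold lower number from compound 1 to compound 4 (0.56 log units; beyond the scatter) and this change also carries from one core to the other: the same change on two cores in this assay, a 2.2-fold lower number (0.34 log units; beyond the scatter) from compound 2 to compound 3 and a 3.6-fold lower number (0.56 log units; beyond the scatter) from compound 1 to compound 4, 1.7-fold (0.22 log units) apart, within the scatter of two such steps. These are two pairs of steps among four compounds in a single cell line, so the two changes combine consistently here, but this does not show that either would carry to other cores or other assays.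

Still open, as far as these compounds go, is how an amine or a longer chain would behave on the saturated ring carbon. Also open, from the compounds shown here alone, is whether a carboxylic acid in place of the ethoxy group would fit the same picture.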